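Moving the Chlorine Around the Aniline Ring

A few compounds are considered here, and "the series" means these few. Any claim that something is new, unique, unknown or untested is made for them only; others in the source may bear on it.

Three compounds have been measured in a functional assay on B16-F10 cells (Mus musculus) for inhibition, read by MTT assay, with a stated time of 72 h; a lower number here means a stronger inhibitor, a higher number a weaker inhibitor:

Compound 1, `COc1ccc(Nc2nc(SCc3cn(Cc4ccccc4Cl)nn3)nc(-c3ccccc3)c2C#N)cc1`, gives 3990 nM.
Compound 2, `N#Cc1c(Nc2cccc(C(F)(F)F)c2)nc(SCc2cn(Cc3ccccc3Cl)nn2)nc1-c1ccccc1`, gives 3710 nM.
Compound 3, `N#Cc1c(Nc2ccccc2Cl)nc(SCc2cn(Cc3ccccc3Cl)nn2)nc1-c1ccccc1`, gives 8350 nM.

Compound 3 stands at the highest number of the three in this assay, which is to say it is the weakest inhibitor shown. The two steps that reach it are both modest and both beyond the scatter: a 2.1-fold higher number from compound 1 to compound 3 (0.32 log units; beyond the scatter) and a 2.3-fold higher number from compound 2 to compound 3 (0.35 log units; beyond the scatter). Between compound 1 and compound 2 the step is a 1.1-fold lower number from compound 1 to compound 2 (0.03 log units; within the scatter), so those two sit together.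

Compound 4, `N#Cc1c(Nc2ccc(Cl)cc2)nc(SCc2cn(Cc3ccccc3Cl)nn2)nc1-c1ccccc1`, differs from compound 3 in one place: 4-chlorophenyl in place of 2-chlorophenyl on a nitrogen on an aromatic ring. For the measured compounds named here, no measured pair makes exactly this change, but the steps from compound 1 and compound 2 into compound 3 suggest that the 2-chlorophenyl arrangement is the one that costs. Shifting the chlorine to give 4-chlorophenyl is therefore expected to bring the number back down toward compound 1 and compound 2, a modest step of about a 1.9-fold lower number from compound 3 to compound 4 (0.27 log units; within the scatter) in this assay. Compound 4 is estimated at 4500 nM in this assay, with a range of 2000 nM to 10000 nM.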

Compound 4, half-maximal inhibitory concentration: 1590 nM
The estimate for compound 4 lay 2.8-fold (0.45 log units) above the measured number; measured number outside the range, below it.
By their numbers in this assay, from the lowest: compound 4; then compounds 2 and 1 (each within the scatter of the next); then compound 3.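

For the compounds shown here, with the same atoms on the nitrogen, 4-chlorophenyl in place of 2-chlorophenyl gives a 5.3-fold lower number from compound 3 to compound 4 (0.72 log units; beyond the scatter) in this assay and so shows that the place of the chlorine alone can move the number, something the earlier compounds could not show because each carried a different group. Compound 4 also stands apart from the other two, with a 2.3-fold lower number from compound 2 to compound 4 (0.37 log units; beyond the scatter) and a 2.5-fold lower number from compound 1 to compound 4 (0.40 log units; beyond the scatter) making it the strongest inhibitor of the four. Nothing available here explains why the place of the chlorine matters in this way.

As far as these compounds go, whether the chlorine itself is needed stays open, since a plain phenyl group, or a bromine or an amine in the chlorine's place, would be the test. Also open, from the compounds shown here alone, is whether the same change would hold on cells other than those of this assay.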